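One Methyl Fewer on the Side Chain of Compound 2

This account rests on a few compounds, and the source may have more. Where it says the series, first, only, none or still open, it means among the compounds named here.

In a functional assay on MKN-45 cells (Homo sapiens) for antiproliferative activity, read by MTT assay, with a stated time of 72 h (on this read-out lower numbers stand for stronger inhibition and higher numbers for weaker inhibition), compound 1 `O=c1c(-c2ccc(F)cc2)c[nH]c2ccnc(Nc3ccc(Oc4ccnc5cc(OCCO)ccc45)c(F)c3)c12` gives 4700 nM, compound 2 `CC(C)(O)COc1ccc2c(Oc3ccc(Nc4nccc5[nH]cc(-c6ccc(F)cc6)c(=O)c45)cc3F)ccnc2c1` gives 2700 nM and compound 3 `COCCOc1cc2nccc(Oc3ccc(Nc4nccc5[nH]cc(-c6ccc(F)cc6)c(=O)c45)cc3F)c2cc1OC` gives 3100 nM. Compound 2 thus stands within the scatter of both others. Compound 4 `CC(O)COc1ccc2c(Oc3ccc(Nc4nccc5[nH]cc(-c6ccc(F)cc6)c(=O)c45)cc3F)ccnc2c1` differs from it by hydrogen in place of methyl on a saturated chain carbon bound to an oxygen on a saturated carbon and two saturated chain carbons, which turns 2-hydroxy-2-methylpropoxy into 2-hydroxypropoxy. Within the data shown here, the one measured step on this chain is a 1.7-fold lower number from compound 1 to compound 2 (0.24 log units; within the scatter), where 1-hydroxy-1-methylethyl replaces hydroxymethyl. Even that larger change in the chain stayed small, so no shift beyond the scatter is expected here. The expected step is a 1.3-fold higher number from compound 2 to compound 4 (0.11 log units; within the scatter). Compound 4 is estimated at 3500 nM, with an expected range of 2000 nM to 6000 nM.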

Compound 4, half-maximal inhibitory concentration: 3100 nM
Compound 4: the middle estimate sits 1.1-fold (0.05 log units) above what was measured; measured number inside the range.
By their numbers in this assay, from the lowest: compounds 2, 3, 4 and 1 (each within the scatter of the next).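

In this assay, this carbon of the chain can now be read one methyl at a time: hydrogen in place of methyl gives (a 1.1-fold higher number from compound 2 to compound 4 (0.06 log units; within the scatter)), and methyl in place of hydrogen, starting from the hydroxyethoxy chain of compound 1, gives (a 1.5-fold lower number from compound 1 to compound 4 (0.18 log units; within the scatter)). Both single steps lie within the scatter, so the three chains cannot be told apart on this read-out. Nothing on hand offers an explanation for this. The compounds shown leave open whether an amine or a carboxylic acid on this chain, or a longer chain, would move the number beyond the scatter.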